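Benzyl to 4-Ethoxyphenyl on the Fused Core

A few compounds are considered here, and "the series" means these few. Any claim that something is new, unique, unknown or untested is made for them only; others in the source may bear on it.

Measured compounds:
- compound 1, `CCOc1ccc(-c2nn3cc(-c4cccc(N)c4)nc3s2)cc1`: in a functional assay on FM3A cells (Mus musculus) for inhibition, read by cell counting, with a stated time of 2 days (a higher number here means a weaker inhibitor, a lower number a stronger inhibitor), compound 1 gives >= 250000 nM, which is a limit of the assay
- compound 2, `C=C(Br)C(=O)Nc1cccc(-c2cn3nc(Cc4cccc(OC)c4)sc3n2)c1`: in this assay compound 2 gives 1100 nM
- compound 3, `C=C(Br)C(=O)Nc1cccc(-c2cn3nc(Cc4ccccc4)sc3n2)c1`: in this assay compound 3 gives 3000 nM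

Compound 3 carries the highest of the two numbers shown; its nearest neighbour is compound 2, and a 2.7-fold higher number from compound 2 to compound 3 (0.44 log units; beyond the scatter). Compound 1 is known only through the limit of >= 250000 nM in this assay, at which 1 of the 3 values shown sits, and gives no number.

Compound 4, `C=C(Br)C(=O)Nc1cccc(-c2cn3nc(-c4ccc(OCC)cc4)sc3n2)c1`, differs from compound 3 in one place: 4-ethoxyphenyl in place of benzyl on an aromatic carbon. For the measured compounds named here, the single measured step, from compound 2 to compound 3, concerns a methoxy on the pendant ring and is modest; no measured step covers an exchange of benzyl for a directly attached aryl ring, so the direction is uncertain. Compound 4 is therefore expected close to compound 3, estimated at 3000 nM with a range from 700 nM to 13000 nM. The expected step is no change at the digits printed from compound 3 to compound 4 (within the scatter).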

Compound 4, half-maximal inhibitory concentration: 1100 nM
Beside the measured number, compound 4's estimate is 2.7-fold (0.44 log units) above it; the measured number falls inside the stated range.
By their numbers in this assay, from the lowest: compounds 2 and 4 (each within the scatter of the next); then compound 3. At a limit, above all of these: compound 1.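

Replacing benzyl with 4-ethoxyphenyl on this aromatic carbon gives a 2.7-fold lower number from compound 3 to compound 4 (0.44 log units; beyond the scatter) and, set against 3-methoxybenzyl, no change at the digits printed from compound 2 to compound 4 (within the scatter) so this position accepts a directly attached aryl ring as well as a benzyl. For the compounds shown here, with 4-ethoxyphenyl held constant, (1-bromoethenyl)carbonyl in place of hydrogen on the nitrogen gives an at least 220-fold lower number from compound 1 to compound 4 (2.35 log units; beyond the scatter) and is the first step to isolate that group. This step rests on a limit for compound 1, not a number: the limit of >= 250000 nM in this assay, at which 1 of the 4 values shown sits.

Still open, on these data alone, is whether the ethoxy matters in compound 4, and how an unsubstituted phenyl or a carboxylic acid on the pendant ring would fare here.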